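The compounds below may be only part of what the source reports. "The series", "measured", "known", "first", "only" and "open" are said of these compounds alone.

Going by the values given here, compound 2 `O=c1ccoc2cc(OCc3cn(Cc4ccccc4Cl)nn3)ccc12` is the one compound here with a definite number in a functional assay on SW480 cells (Homo sapiens) for cytotoxicity, read by MTT assay, with a stated time of 48 h; a higher number here means a weaker inhibitor, a lower number a stronger inhibitor: compound 2 gives 23500 nM. Compound 1 `Cc1ccccc1Cn1cc(COc2ccc3c(=O)ccoc3c2)nn1` carries a methyl where compound 2 carries a chloro. In this assay compound 1 reaches only a limit of the assay, namely > 100000 nM. That value is a limit and not a measurement, as the limit of > 100000 nM in this assay, at which 1 of the 2 values shown sits, records. Among the compounds with values here, the single measured step, an at least 4.2-fold lower number from compound 1 to compound 2 (0.62 log units; beyond the scatter), shows the chloro compound inhibiting more strongly than the methyl compound, though the true size of that step cannot be fixed because compound 1 sits at > 100000 nM.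

Compound 3 `O=c1ccoc2cc(OCc3cn(Cc4cccc(Cl)c4)nn3)ccc12` differs from compound 2 only in 3-chlorophenyl in place of 2-chlorophenyl on a saturated chain carbon bound to an aromatic nitrogen. Within the data shown here, no measured step moves a group from one place to another on that ring; the one step known concerns the kind of group, not where it sits, so it gives little guidance here. The expected step of a 1.1-fold lower number from compound 2 to compound 3 (0.03 log units; within the scatter) is therefore small, and no change beyond the scatter is foreseen in either direction. Compound 3 is expected to give 22000 nM, within a range from 8000 nM to 70000 nM.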

Compound 3, half-maximal inhibitory concentration: 12900 nM
The estimate for compound 3 lay 1.7-fold (0.23 log units) above the measured number; the measured number falls inside the stated range.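

In this assay, going from 2-chlorobenzyl to 3-chlorobenzyl gives a 1.8-fold lower number from compound 2 to compound 3 (0.26 log units; within the scatter) and so this assay does not separate these two placements of the chloro group on the ring. Exchanging 2-methylphenyl for 3-chlorophenyl gives an at least 7.7-fold lower number from compound 1 to compound 3 (0.88 log units; beyond the scatter) and this means that both chloro compounds now stand apart from the methyl compound, whichever of the two placements the chloro group takes. The true size of this second step cannot be fixed because the value for compound 1 is a limit and not a number: the limit of > 100000 nM in this assay, at which 1 of the 3 values shown sits.

On these data alone, the comparison between methyl and chloro still rests on a single methyl compound, so it remains open whether a methyl group placed as the chloro group is in compound 3 would also stay out of measurable range. As far as these compounds go, it is equally open how this ring would behave with a fluoro, bromo or trifluoromethyl group in place of the chloro group, or with a more different substituent such as an amine or a carboxylic acid.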